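The compounds below may be only part of what the source reports. "The series", "measured", "known", "first", "only" and "open" are said of these compounds alone.

In an assay on cells for antagonist activity at transient receptor potential cation channel subfamily V member 1 (Homo sapiens), read by FLIPR and calcium flux, with a stated time of 6 min (a lower number here means a stronger inhibitor, a higher number a weaker inhibitor), compound 1 `CCCCN(C)c1nc(C(C)(C)C)ccc1CNC(=O)C(C)c1ccc(NS(C)(=O)=O)c(F)c1` gives 1.2 nM, compound 2 `CCC1CCN(c2nc(C(C)(C)C)ccc2CNC(=O)C(C)c2ccc(NS(C)(=O)=O)c(F)c2)CC1` gives 0.1 nM, and compound 3 `CC(C)COc1nc(C(C)(C)C)ccc1CNC(=O)C(C)c1ccc(NS(C)(=O)=O)c(F)c1` gives 0.6 nM. Compound 3 thus stands second highest of the three numbers, nearest to compound 1 and furthest from compound 2. All three measured steps change the group attached to the aromatic carbon of the shared core: a 12-fold lower number from compound 1 to compound 2 (1.08 log units; beyond the scatter), a 2.0-fold lower number from compound 1 to compound 3 (0.30 log units; within the scatter), and a 6.0-fold higher number from compound 2 to compound 3 (0.78 log units; beyond the scatter). Compound 4 `CC(C(=O)NCc1ccc(C(C)(C)C)nc1OCc1ccc(F)cc1)c1ccc(NS(C)(=O)=O)c(F)c1` differs from compound 3 by 4-fluorophenyl in place of isopropyl on a saturated chain carbon bound to an oxygen on an aromatic ring. For the measured compounds named here, only the step from compound 1 to compound 2 brought a ring into this part of the molecule, and that was the large step, whereas swapping an amine-linked group for an ether-linked one stayed within the scatter. A ring entering on the ether chain is therefore expected to give a modest step toward a lower number or none beyond the scatter, a 1.5-fold lower number from compound 3 to compound 4 (0.18 log units; within the scatter). Compound 4 is accordingly estimated at 0.4 nM in this assay, with a range from 0.1 nM to 2 nM.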

Compound 4, inhibition constant: 0.8 nM
Beside the measured number, compound 4's estimate is 2.0-fold (0.30 log units) below it; the measured number falls inside the stated range.
By their numbers in this assay, from the lowest: compound 2; then compounds 3, 4 and 1 (each within the scatter of the next).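

On the saturated chain carbon bound to an oxygen on an aromatic ring, 4-fluorophenyl can stand in place of isopropyl with no change beyond the scatter, a 1.3-fold higher number from compound 3 to compound 4 (0.12 log units; within the scatter), so a ring at this place neither gains nor loses measurably in this assay. The ring carried on the ether chain also does not match the effect of 4-ethylpiperidin-1-yl: an 8.0-fold higher number from compound 2 to compound 4 (0.90 log units; beyond the scatter) lies beyond the scatter, while a 1.5-fold lower number from compound 1 to compound 4 (0.18 log units; within the scatter) stays within it, leaving compound 2 apart from compounds 1, 3 and 4. No available evidence bears on what lies behind these results.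

The compounds shown leave open whether plain benzyl, without the fluorine, would behave as (4-fluorobenzyl)oxy does here. They also leave open how a longer chain carrying the 4-fluorophenyl, or an amine or carboxylic acid on the ether chain, would read in this assay.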